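Carbamate series: benzyl in place of propargyl on the amine

A few compounds are considered here, and "the series" means these few. Any claim that something is new, unique, unknown or untested is made for them only; others in the source may bear on it.

Measured so far in an assay on BTI-TN-5B1-4 cells for inhibition of Amine oxidase [flavin-containing] A (Homo sapiens), read by fluorescence and Amplex Red, using microsomes, with a stated time of 15 min; on this read-out higher numbers stand for weaker inhibition and lower numbers for stronger inhibition:
- compound 1 `C#CCN1CCCC(OC(=O)Nc2ccccc2)C1`, a limit only: > 100000 nM
- compound 2 `C#CCN1CCCC(COC(=O)Nc2ccc(C(C)C)cc2)C1`, a limit only: > 100000 nM

Compound 2 stands at the limit of this assay, not at a number. Compound 1 stands at the same limit, so the two values show no order between them; both sit at the limit of > 100000 nM in this assay, at which 2 of the 2 values shown sit.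

Compound 3 `CC(C)c1ccc(NC(=O)OCC2CCCN(Cc3ccccc3)C2)cc1` is not yet measured. It differs from compound 2 by phenyl in place of ethynyl on a saturated chain carbon bound to an amine nitrogen in a ring; cut one bond further out, propargyl becomes benzyl.

Among the measured compounds shown here, no step between measured compounds is available, and the value of compound 2 is a limit, so no measured step can guide the size or direction. The step from compound 2 to compound 3 is expected to be a number no higher from compound 2 to compound 3 (the limit leaves the size open), most likely none beyond the scatter. Compound 3 is therefore expected near 100000 nM, within 20000 nM to 300000 nM, with a fair chance that only a limit is reported again.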

Compound 3, half-maximal inhibitory concentration: > 100000 nM
Compound 3 was reported as a limit; the forecaster's own chance of this, stated with the estimate: 65%; the middle value sits exactly at the limit.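

In this assay compound 3 gives > 100000 nM, a limit. Compound 2 is held at a limit as well, so no step can be read between compound 2 and compound 3. The compounds shown leave open whether propargyl and benzyl on the amine differ at all in this assay.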